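Sulfonamide amine variation on the alkyne-linked phenoxyacetic acid series

A few compounds are considered here, and "the series" means these few. Any claim that something is new, unique, unknown or untested is made for them only; others in the source may bear on it.

Measured compounds:
- compound 1, `COCCN(C)S(=O)(=O)c1ccc(C)c(C#Cc2cc(Cl)ccc2OCC(=O)O)c1`: 77 nM
- compound 2, `CS(=O)(=O)c1ccc(F)c(C#Cc2cc(Cl)ccc2OCC(=O)O)c1`: 95 nM
- compound 3, `Cc1ccc(S(=O)(=O)N(C)C)cc1C#Cc1cc(Cl)ccc1OCC(=O)O`: 77 nM

In a functional assay on cells for antagonist activity at prostaglandin D2 receptor 2 (Homo sapiens), read by flow cytometry, with a stated time of 10 min (a higher number here means a weaker inhibitor, a lower number a stronger inhibitor), compound 1 sits level with compound 3, the two together giving the lowest numbers of the three; compound 2 reads slightly higher, but within the scatter, so no order among the three can be stated.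

The next compound is compound 4, `Cc1ccc(S(=O)(=O)N2CCCCC2C)cc1C#Cc1cc(Cl)ccc1OCC(=O)O`. Relative to compound 1 it carries 2-methylpiperidin-1-yl in place of (2-methoxyethyl)(methyl)amino on a sulfonyl sulfur.

Among the measured compounds shown here, the only measured step that bears on this is no change at the digits printed from compound 1 to compound 3 (within the scatter): trimming the chain on the sulfonamide nitrogen left the number unchanged, so the amine substituent on the sulfonyl sulfur appears to tolerate variation of that kind, at least between compound 1 and compound 3. For the measured compounds named here, no measured pair shows what closing the amine into a six-membered non-aromatic ring does, nor what the loss of the single hydrogen-bond acceptor does. Given that, the expected step of a 1.2-fold higher number from compound 1 to compound 4 (0.07 log units; within the scatter) is small and not clearly beyond the scatter in either direction, with the range widened for the untested ring. Compound 4 is therefore estimated at 90 nM, between 35 nM and 250 nM.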

Compound 4, half-maximal inhibitory concentration: 310 nM
Compound 4: the middle estimate sits 3.4-fold (0.54 log units) below what was measured, and the stated range ends below it.
By their numbers in this assay, from the lowest: compounds 1, 3 and 2 (each within the scatter of the next); then compound 4.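

In this assay, the amine on the sulfonyl sulfur proves less freely variable than the earlier pair suggested: 2-methylpiperidin-1-yl in place of (2-methoxyethyl)(methyl)amino gives a 4.0-fold higher number from compound 1 to compound 4 (0.60 log units; beyond the scatter), and in place of dimethylamino it gives a 4.0-fold higher number from compound 3 to compound 4 (0.60 log units; beyond the scatter). This is the first change at this position shown to move the number beyond the scatter, and it separates the cyclic amine of compound 4 from the two amines without a ring, which read level with each other. No supporting data bear on the cause of this step.

With only one cyclic amine shown, the ring itself and its 2-methyl group cannot be told apart as the source of the step, so the open comparison is with piperidin-1-yl lacking that methyl, and with pyrrolidin-1-yl as a smaller ring. Morpholin-4-yl would show how a ring oxygen reads here, and a secondary sulfonamide such as methylamino would extend the comparison to a nitrogen that still carries a hydrogen.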